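Removing the chloro from a weak chromone dithiocarbamate

The source may report more compounds than this note shows. Statements on the series, on what has been measured and on what is new or still open speak of the compounds shown alone.

Compound 1 `O=c1cc(CSC(=S)N2CCCCC2)oc2ccccc12` and compound 2 `O=c1cc(CSC(=S)N2CCOCC2)oc2cc(Cl)ccc12` share a core and differ in the ring amine and in a chloro on the fused aromatic ring. In a functional assay on HeLa cells (Homo sapiens) for antiproliferative activity, read by MTT assay, with a stated time of 72 h (on this read-out higher numbers stand for weaker inhibition and lower numbers for stronger inhibition), compound 1 reaches only a limit of the assay, > 25000 nM, consistent with the limit of > 25000 nM in this assay, at which 1 of the 2 values shown sits. In this assay, among the measured compounds shown here, compound 2 gives 33300 nM, the only numerical value shown. Compound 3 `O=c1cc(CSC(=S)N2CCOCC2)oc2ccccc12` is not yet measured; it differs from compound 2 by hydrogen in place of chloro on an aromatic carbon. For the measured compounds named here, no measured step is available for this change. Both known values are weak, so the step is expected to stay within the scatter, or to drift toward still weaker inhibition; the expected step from compound 2 to compound 3 is a 1.2-fold higher number from compound 2 to compound 3 (0.08 log units; within the scatter). Compound 3 is therefore estimated at 40000 nM, with a range from 15000 nM to 120000 nM, and a real chance that only a limit is reported.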

Compound 3, half-maximal inhibitory concentration: 35600 nM
Beside the measured number, compound 3's estimate is 1.1-fold (0.05 log units) above it, within the range that was stated.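

In this assay, among the compounds shown here, hydrogen in place of chloro on an aromatic carbon gives a 1.1-fold higher number from compound 2 to compound 3 (0.03 log units; within the scatter), the first readable step at this position. With morpholin-4-yl held fixed, the chloro therefore makes no difference beyond the scatter, and compound 3 remains in the same weak range without it. The change from piperidin-1-yl to morpholin-4-yl, from compound 1 to compound 3, cannot be read, because compound 1 gives only a limit of the assay: the limit of > 25000 nM in this assay, at which 1 of the 3 values shown sits.

The compounds shown leave open whether this aromatic carbon responds to anything other than chloro and hydrogen, such as a methoxy group, an amine or a carboxylic acid. They also leave open whether another ring amine on the thiocarbonyl carbon, such as piperazin-1-yl, would give a stronger number.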